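A few compounds are considered here, and "the series" means these few. Any claim that something is new, unique, unknown or untested is made for them only; others in the source may bear on it.

Measured so far in an ADME assay on Huh-7 cells (Homo sapiens) for cytotoxicity; a higher number here means a weaker inhibitor of growth, a lower number a stronger inhibitor of growth:

- compound 1 `COc1cc2c(=O)c(C(=O)c3ccc(C)cc3)cn(Cc3ccccc3)c2cc1OC` — compound 1 gives "not active" (no number reported)
- compound 2 `COc1cc2c(=O)c(C(=O)c3ccc(C)cc3)cn(CCCc3ccccc3)c2cc1OC` — compound 2 gives "not active" (no number reported)
- compound 3 `COc1cc2c(=O)c(C(=O)c3ccc(C)cc3)cn(Cc3ccc(S(C)(=O)=O)cc3)c2cc1OC` — compound 3 gives > 50000 nM

The series shares one core and varies only the group on the ring nitrogen. None of the three entries carries a single number. For compound 3 the reported value is a limit of this assay and not a measured number; compound 3 therefore stands at the limit of > 50000 nM in this assay, at which 1 of the 3 values shown sits. For the measured compounds named here, compounds 1 and 2 give no figure at all, so no step between measured compounds can be drawn, and nothing in this set ranks one compound against another.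

Compound 4 `COc1cc2c(=O)c(C(=O)c3ccc(C)cc3)cn(Cc3ccc(C(C)(C)C)cc3)c2cc1OC` is the next entry. It differs from compound 3 in one place: tert-butyl in place of methylsulfonyl on an aromatic carbon. Going by the values given here, no measured step exists for this exchange, and no entry in this assay points toward growth inhibition in the measurable range. The expected step that the limit leaves unreadable from compound 3 to compound 4 is none beyond the usual scatter. Compound 4 is expected to give 60000 nM in this assay, within 25000 nM to 150000 nM, most likely reported again only as a limit.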

Compound 4, concentration for 50% growth inhibition: > 25000 nM
Compound 4: only a limit was reported (the forecaster's own chance of this, stated with the estimate: 75%); the middle value does not contradict the limit.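

For the compounds shown here, compound 3 and compound 4 are both entered in this assay only as limits, and no step between them can be read. The compounds shown leave open whether any member of this series inhibits growth at a measurable concentration, and whether the group on the ring nitrogen alters that.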